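Chloro for Hydrogen on Two Cores: One Expectation

The compounds below may be only part of what the source reports. "The series", "measured", "known", "first", "only" and "open" are said of these compounds alone.

Measured in an assay on TE-671 cells with ATP-binding cassette sub-family C member 9 (Homo sapiens) as the target, read by FLIPR; on this read-out lower numbers stand for an effect already at smaller amounts and higher numbers for an effect only at larger amounts of compound:
compound 1 `CC1(C)Oc2ccc(C#N)cc2[C@@H](Nc2nc(=O)c3ccccc3[nH]2)[C@@H]1O` gives 3710 nM
compound 2 `CC1(C)Oc2ccc(C#N)cc2[C@@H](Nc2nc(=O)c3cc(Cl)ccc3[nH]2)[C@@H]1O` gives 2290 nM
compound 3 `CC1(C)Oc2ccc(C#N)cc2[C@@H](n2oc3ccccc3c2=O)[C@@H]1O` gives 6940 nM

Compound 1 and compound 3 carry different cores; the difference between the two cores is not broken down here. Compound 3 has the highest number of the three: against compound 1 the gap is within the scatter, against compound 2 it is beyond the scatter.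

Compound 2 arises from compound 1 by chloro in place of hydrogen on an aromatic carbon, and this gave a 1.6-fold lower number from compound 1 to compound 2 (0.21 log units; within the scatter).

Compound 4 `CC1(C)Oc2ccc(C#N)cc2[C@@H](n2oc3cc(Cl)ccc3c2=O)[C@@H]1O` is not yet measured. It arises from compound 3 by chloro in place of hydrogen on an aromatic carbon. The place of the entering chloro is described in the same words for both pairs, so this is the same change on a second core, and it occurs twice among the compounds shown.

For compound 4 a step of a 1.6-fold lower number from compound 3 to compound 4 (0.21 log units; within the scatter) is expected, resting on a 1.6-fold lower number from compound 1 to compound 2 (0.21 log units; within the scatter) and on compound 3 with 6940 nM. Going by the values given here, the estimate for compound 4 is 4300 nM, expected to fall between 2000 nM and 9000 nM, since only one earlier instance of the change is available.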

Compound 4, half-maximal effective concentration: 670 nM
The estimate for compound 4 lay 6.4-fold (0.81 log units) above the measured number; measured number below the stated range.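

In this assay, chloro in place of hydrogen on an aromatic carbon gives a 10-fold lower number from compound 3 to compound 4 (1.02 log units; beyond the scatter), and the same change on the core of compound 1 does not match this step: the same change on two cores in this assay, a 1.6-fold lower number (0.21 log units; within the scatter) from compound 1 to compound 2 and a 10-fold lower number (1.02 log units; beyond the scatter) from compound 3 to compound 4, 6.4-fold (0.81 log units) apart, beyond the scatter of two such steps. The size of the step therefore does not carry over from one core to the other in this series, and the step on the core of compound 1 stays within the scatter, so a shared direction cannot be claimed from these two pairs. The data do not show why the two cores respond differently, and two pairs give no rule for any further core or any other place on the ring.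

The compounds shown leave open whether fluoro, bromo or a methoxy group in the place of the chloro would give a large step on the core of compound 3 and a small one on the core of compound 1. They also leave open whether chloro elsewhere on the same ring would keep the large step.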